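The source may report more compounds than this note shows. Statements on the series, on what has been measured and on what is new or still open speak of the compounds shown alone.

Measured in a functional assay on A549 cells (Homo sapiens) for cytotoxicity, read by MTT assay, with a stated time of 72 h; a lower number here means a stronger inhibitor, a higher number a weaker inhibitor:
- compound 1 `CNC(=O)c1cc(Oc2ccc(NC(=O)c3cc(-c4ccc(Br)cc4)ncn3)cc2)ccn1`: > 100000 nM (a limit of the assay)
- compound 2 `CNC(=O)c1cc(Oc2ccc(NC(=O)c3cc(-c4ccc(OC)cc4)ncn3)cc2F)ccn1`: 34500 nM

Among the measured compounds shown here, compound 2, at 34500 nM, holds the only actual number so far. Compound 3 `CNC(=O)c1cc(Oc2ccc(NC(=O)c3cc(-c4ccc(OC)cc4)ncn3)cc2)ccn1` has hydrogen in place of fluoro on an aromatic carbon, ortho to a (2-(methylcarbamoyl)pyridin-4-yl)oxy group: hydrogen in place of fluoro on an aromatic carbon. For the measured compounds named here, no measured pair isolates this change, so no shift beyond the usual scatter is expected in this assay. The expected change is a 1.2-fold higher number from compound 2 to compound 3 (0.09 log units; within the scatter). For compound 3 the estimated value is 42000 nM, with an expected range of 15000 nM to 100000 nM.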

Compound 3, half-maximal inhibitory concentration: 13500 nM
Compound 3: the middle estimate sits 3.1-fold (0.49 log units) above what was measured, and the stated range ends above it.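

In this assay, hydrogen in place of fluoro on this aromatic carbon, ortho to a (2-(methylcarbamoyl)pyridin-4-yl)oxy group, gives a 2.6-fold lower number from compound 2 to compound 3 (0.41 log units; beyond the scatter), so this position registers in the read-out, and in the direction of a stronger inhibitor. Methoxy in place of bromo gives an at least 7.4-fold lower number from compound 1 to compound 3 (0.86 log units; beyond the scatter). Compound 1 stands at a limit, so that step has only a lower bound: the limit of > 100000 nM in this assay, at which 1 of the 3 values shown sits.

Going by these compounds, whether the fluoro step holds with bromo in place of methoxy remains open. So does the effect of an amine or a carboxylic acid in place of the methoxy.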